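Phenyl in place of 3,4-dimethylphenyl on the amine

The source may report more compounds than this note shows. Statements on the series, on what has been measured and on what is new or still open speak of the compounds shown alone.

Compound 1 `O=C1C=C(Nc2ccccc2F)C(=O)c2c1nc1n2[C@H]2OC[C@@H](O)[C@H]2OC1`: 2080 nM
Compound 2 `Cc1ccc(NC2=CC(=O)c3nc4n(c3C2=O)[C@H]2OC[C@@H](O)[C@H]2OC4)cc1C`: 860 nM

Among the compounds with values here, in a functional assay on MGC-803 cells (Homo sapiens) for inhibition, read by sulforhodamine B assay (a higher number here means a weaker inhibitor, a lower number a stronger inhibitor), compound 2 gives 860 nM, the lower of the two numbers measured so far. Compound 3 `O=C1C=C(Nc2ccccc2)C(=O)c2c1nc1n2[C@H]2OC[C@@H](O)[C@H]2OC1`, not yet measured, carries this change: phenyl in place of 3,4-dimethylphenyl on an amine nitrogen. In words, it has phenyl in place of 3,4-dimethylphenyl on an amine nitrogen. Within the data shown here, only one measured step bears on this, the modest 2.4-fold lower number from compound 1 to compound 2 (0.38 log units; beyond the scatter), which brought 3,4-dimethylphenyl in place of 2-fluorophenyl. A modest rise in this assay is therefore expected, back toward compound 1 at 2080 nM. The expected change is a 1.6-fold higher number from compound 2 to compound 3 (0.21 log units; within the scatter). For compound 3 the estimated value is 1400 nM, with an expected range of 550 nM to 3500 nM.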

Compound 3, half-maximal inhibitory concentration: 1730 nM
The estimate for compound 3 lay 1.2-fold (0.09 log units) below the measured number, within the range that was stated.
By their numbers in this assay, from the lowest: compounds 2, 3 and 1 (each within the scatter of the next, the first and the last beyond it).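

In this assay, the plain anilino compound cannot be separated from either neighbour: phenyl in place of 3,4-dimethylphenyl gives a 2.0-fold higher number from compound 2 to compound 3 (0.30 log units; within the scatter), and hydrogen in place of fluoro on an aromatic carbon gives a 1.2-fold lower number from compound 1 to compound 3 (0.08 log units; within the scatter). Neither single change to the ring on this amine nitrogen therefore registers on its own, although the step between the two substituted rings lies beyond the scatter. Nothing measured here offers an explanation for these numbers.

As far as these compounds go, a methoxy group or a carboxylic acid on the phenyl ring remains open, as does a benzyl group or a longer alkyl chain on this amine nitrogen.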